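Chain extension from compound 3 to compound 4

The source may hold more compounds than are shown below. What is called first, only, known or untested is meant among the compounds shown, and "the series" means these compounds.

In a functional assay on MOLT-4 cells (Homo sapiens) for antiproliferative activity, read by MTT assay, with a stated time of 48 h (a lower number here means a stronger inhibitor, a higher number a weaker inhibitor), compound 3 (`O=C(CCCCCn1cc(Nc2ncc(Cl)c(Nc3ccc(Cl)cc3)n2)cn1)NO`) gives 80 nM. This is within the scatter of compound 2 (`CNc1nc(Nc2cnn(CCCCCCC(=O)NO)c2)ncc1Cl`) at 110 nM, while compound 1 (`COc1ccc(Nc2nc(Nc3cnn(CCCCCCC(=O)NO)c3)ncc2Cl)cc1`) at 170 nM lies beyond the scatter on the higher side. The change to compound 4 (`O=C(CCCCCCn1cc(Nc2ncc(Cl)c(Nc3ccc(Cl)cc3)n2)cn1)NO`) is (hydroxycarbamoyl)methyl in place of hydroxycarbamoyl on a saturated chain carbon, five bonds along the chain from an aromatic nitrogen. Among the measured compounds shown here, no measured step tests this change directly. The chain of compound 4 also occurs in the other two measured compounds, and their step, a 1.5-fold lower number from compound 1 to compound 2 (0.19 log units; within the scatter), sits on a nitrogen on an aromatic ring and stays within the scatter. No step beyond the scatter is therefore expected in this assay, and the estimated step is a 1.1-fold higher number from compound 3 to compound 4 (0.05 log units; within the scatter). Compound 4 is expected at 90 nM, with an estimated range of 35 nM to 220 nM.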

Compound 4, half-maximal inhibitory concentration: 120 nM
Compound 4: middle estimate off by 1.3-fold (0.12 log units), on the low side; the range from low to high includes it.
By their numbers in this assay, from the lowest: compounds 3, 2, 4 and 1 (each within the scatter of the next, the first and the last beyond it).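

In this assay, among the compounds shown here, (hydroxycarbamoyl)methyl in place of hydroxycarbamoyl gives a 1.5-fold higher number from compound 3 to compound 4 (0.18 log units; within the scatter) as the first direct reading of this change on the saturated chain. With the chain of compound 4 held, 4-chlorophenyl in place of methyl gives a 1.1-fold higher number from compound 2 to compound 4 (0.04 log units; within the scatter) and chloro in place of methoxy gives a 1.4-fold lower number from compound 1 to compound 4 (0.15 log units; within the scatter) so all three new steps stay within the scatter. No measurement at hand bears on the reason for these readings.

On these data alone, a longer chain at this position remains open, as does a carboxylic acid in place of the hydroxycarbamoyl end.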